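Swapping a furan ring for a pentyl chain on the amide nitrogen

The compounds below may be only part of what the source reports. "The series", "measured", "known", "first", "only" and "open" are said of these compounds alone.

Compound 1, `Cc1nc(N)sc1CCCN/C(N)=N/C(=O)N[C@H](C)c1ccccc1`, gives 0.95 in a functional assay on Right cardiac atrium for agonist activity at histamine H2 receptor (Cavia porcellus), with a stated time of 30 min, in the presence of a further agent that is not named here; a lower number here means a smaller maximal response, a higher number a larger maximal response.
Compound 2, `Cc1nc(N)sc1CCCN/C(N)=N/C(=O)NCc1ccco1`, gives 0.58 in this assay.

Going by the values given here, compound 2 stands lowest of the two measured values; the only step that reaches it, a number 0.37 lower from compound 1 to compound 2 (beyond the scatter), shows that the group on the amide-type nitrogen can shift the maximal response strongly. Compound 3, `CCCCCCNC(=O)/N=C(\N)NCCCc1sc(N)nc1C`, carries this change: pentyl in place of furan-2-yl on a saturated chain carbon bound to an amide-type nitrogen. Among the compounds with values here, no measured step exchanges a ring for a chain at this place, so the direction is open; the one known step only sets the plausible size. For compound 3 a step of a number 0.12 higher from compound 2 to compound 3 (beyond the scatter) is expected, giving an estimated 0.7 with a range from 0.4 to 1.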

Compound 3, intrinsic activity: the largest response reached, as a fraction of the reference agonist's: 0.95
For compound 3 the middle estimate is 0.25 below the measured one, within the range that was stated.
By their numbers in this assay, from the lowest: compound 2; then compounds 1 and 3 (each within the scatter of the next).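

In this assay, the move to pentyl gives a number 0.37 higher from compound 2 to compound 3 (beyond the scatter), so at this place the furan ring is not needed for a large maximal response. Hexyl in place of 1-phenylethyl gives no change at the digits printed from compound 1 to compound 3 (within the scatter), so an open chain and a phenyl-bearing group serve alike here, and only the (furan-2-yl)methyl compound stands apart. Nothing available explains why the furan compound reaches a smaller maximal response.

From the compounds shown here alone, whether a shorter chain such as propyl or a longer chain such as octyl keeps this response stays open. So does the effect of an amine at the end of the chain.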